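Fluorophenyl sulfone on the piperidinyl core: an expectation

The source may hold more compounds than are shown below. What is called first, only, known or untested is meant among the compounds shown, and "the series" means these compounds.

Compound 1 `CN1CCC(n2cc(S(=O)(=O)c3ccccc3F)c3cccnc32)C1`: 5.6 nM
Compound 2 `O=S(=O)(c1ccccc1Cl)c1cn(C2CCCNC2)c2ncccc12`: 3.7 nM
Compound 3 `O=S(=O)(c1cccc(Br)c1)c1cn(C2CCCNC2)c2ncccc12`: 3.8 nM

Of the compounds shown here, three have been measured in an assay on HeLa cells for displacement of a labelled ligand from 5-hydroxytryptamine receptor 6 (Homo sapiens); a higher number here means a weaker inhibitor, a lower number a stronger inhibitor. Compound 1 carries a 2-fluorophenyl sulfone on a core that differs from the other two, and in this assay compound 1 gives 5.6 nM. Compound 2 and compound 3 share a second core; in this assay compound 2 gives 3.7 nM and compound 3 gives 3.8 nM. Compound 3 stands second highest of the three numbers, with compound 2 nearest and compound 1 furthest, both within the scatter. Among the compounds with values here, the one single-point step among the measured compounds, a 1.0-fold higher number from compound 2 to compound 3 (0.01 log units; within the scatter), shows that exchanging the aryl group on the sulfonyl sulfur left the number essentially unchanged.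

Compound 4 `O=S(=O)(c1ccccc1F)c1cn(C2CCCNC2)c2ncccc12` is the next step: 2-fluorophenyl in place of 3-bromophenyl on a sulfonyl sulfur. The step from compound 2 to compound 3 bears directly on it, since it also swaps the aryl group on the sulfonyl sulfur, and it lay within the scatter. Compound 1, which already carries the 2-fluorophenyl group on a different core, gives a number within the scatter of compound 3. The expected step is therefore a 1.2-fold higher number from compound 3 to compound 4 (0.07 log units; within the scatter), that is, no change beyond the scatter. Compound 4 is estimated at 4.5 nM, with a range from 2 nM to 10 nM.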

Compound 4, inhibition constant: 2 nM
Beside the measured number, compound 4's estimate is 2.3-fold (0.35 log units) above it, within the range that was stated.
By their numbers in this assay, from the lowest: compounds 4, 2, 3 and 1 (each within the scatter of the next, the first and the last beyond it).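

In this assay the three aryl groups on the sulfonyl sulfur of the shared core remain within the scatter of one another: the change to 2-fluorophenyl gives a 1.9-fold lower number from compound 3 to compound 4 (0.28 log units; within the scatter) and, as fluoro in place of chloro on an aromatic carbon, a 1.9-fold lower number from compound 2 to compound 4 (0.27 log units; within the scatter) on the same core, so neither the halogen nor the aryl pattern among these compounds separates them. Within the data shown here, the only step here that passes the scatter lies elsewhere and is modest, with the 2-fluorophenyl group held constant: a 2.8-fold lower number from compound 1 to compound 4 (0.45 log units; beyond the scatter) accompanies piperidin-3-yl in place of 1-methylpyrrolidin-3-yl on an aromatic nitrogen, the first sign that this group can move the number. No measurement offered here explains either result.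

That step changes the ring and the methyl group together, so the compounds shown cannot say which of the two matters, and 1-methylpiperidin-3-yl or pyrrolidin-3-yl on the same nitrogen would separate them. They also leave open whether the sulfonyl sulfur tolerates groups beyond halogenated phenyl, such as an unsubstituted phenyl, a methoxyphenyl or a pyridyl ring.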